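Swapping a Chlorophenyl Amide for a Trifluoromethyl Analogue

The compounds below may be only part of what the source reports. "The series", "measured", "known", "first", "only" and "open" are said of these compounds alone.

Three amides on a shared core have been measured in a functional assay on HT-29 cells (Homo sapiens) for antiproliferative activity, read by sulforhodamine B assay, with a stated time of 72 h; on this read-out lower numbers stand for stronger inhibition and higher numbers for weaker inhibition. Compound 1 (`O=C(Cn1nc(Cc2ccccc2)c2ccccc2c1=O)Nc1ccc(F)cc1`) gives 98000 nM, compound 2 (`O=C(Cn1nc(Cc2ccccc2)c2ccccc2c1=O)Nc1cccc(Cl)c1`) gives 3680 nM, and compound 3 (`O=C(Cn1nc(Cc2ccccc2)c2ccccc2c1=O)Nc1ccc(Cl)cc1`) gives 2980 nM. Compound 3 thus sits at the low end of the three numbers, level with the other chloro compound: the data show a 1.2-fold lower number from compound 2 to compound 3 (0.09 log units; within the scatter). The fluoro compound lies far away, with a 27-fold lower number from compound 1 to compound 2 (1.43 log units; beyond the scatter) and a 33-fold lower number from compound 1 to compound 3 (1.52 log units; beyond the scatter).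

Compound 4 (`O=C(Cn1nc(Cc2ccccc2)c2ccccc2c1=O)Nc1cccc(C(F)(F)F)c1`) carries 3-(trifluoromethyl)phenyl in place of 4-chlorophenyl on an amide-type nitrogen. Going by the values given here, no measured compound carries this group, so the steps offer only indirect guidance. The small step between the two chloro compounds points to little change, while the large steps from compound 1 show that this substituent can matter greatly, which widens the range on the weaker side. The expected step is small and in no firm direction, a 1.7-fold higher number from compound 3 to compound 4 (0.22 log units; within the scatter). The estimated value for compound 4 is 5000 nM, with an expected range of 1500 nM to 18000 nM.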

Compound 4, half-maximal inhibitory concentration: 61000 nM
For compound 4 the middle estimate is 12-fold (1.09 log units) below the measured one; measured number above the stated range.
By their numbers in this assay, from the lowest: compounds 3 and 2 (each within the scatter of the next); then compounds 4 and 1 (each within the scatter of the next).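

In this assay, the group on the amide-type nitrogen proves sensitive beyond the single fluoro case: 3-(trifluoromethyl)phenyl in place of 4-chlorophenyl gives a 20-fold higher number from compound 3 to compound 4 (1.31 log units; beyond the scatter), and trifluoromethyl in place of chloro on an aromatic carbon gives a 17-fold higher number from compound 2 to compound 4 (1.22 log units; beyond the scatter). The large loss is therefore not unique to compound 1, and the two fluorine-bearing amides stand level, with a 1.6-fold lower number from compound 1 to compound 4 (0.21 log units; within the scatter), so these four compounds split into a chloro pair and a fluorine-bearing pair, with no exception among them. No measured evidence accounts for this split.

From the compounds shown here alone, whether chloro is special remains open, as a bromo, methyl or methoxy group on the same phenyl ring could fall with either pair. Compound 1 and compound 4 also differ in both substituent and its place on the ring, so the contribution of each cannot be separated.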